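From 4-hydroxypiperidin-1-yl to (2-hydroxyethyl)amino in compound 1

A few compounds are considered here, and "the series" means these few. Any claim that something is new, unique, unknown or untested is made for them only; others in the source may bear on it.

Compound 1 `CCc1nc2c(C)cc(-c3ccc(CN4CCC(O)CC4)cc3)cn2c1NC(=O)OCc1cc(Cl)cc(Cl)c1`: 5320 nM
Compound 2 `CCc1nc2c(C)cc(-c3ccc(CN4CCC(C)CC4)cc3)cn2c1NC(=O)OCc1cc(Cl)cc(Cl)c1`: 3980 nM

For the measured compounds named here, in a functional assay on MCF7 cells (Homo sapiens) for inhibition, read by MTT assay, with a stated time of 72 h (a lower number here means a stronger inhibitor, a higher number a weaker inhibitor), compound 1 gives 5320 nM and compound 2 gives 3980 nM as its only measured neighbour, so the two stand within the scatter of each other. Going by the values given here, the single measured step, a 1.3-fold lower number from compound 1 to compound 2 (0.13 log units; within the scatter) for methyl in place of hydroxy on a saturated ring carbon, does not separate them.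

Compound 3 `CCc1nc2c(C)cc(-c3ccc(CNCCO)cc3)cn2c1NC(=O)OCc1cc(Cl)cc(Cl)c1` has not yet been measured. The change from compound 1 is (2-hydroxyethyl)amino in place of 4-hydroxypiperidin-1-yl on a saturated chain carbon bound to an aromatic carbon on a saturated chain carbon bound to an aromatic carbon, so the ring goes while a hydroxy group stays. Among the compounds with values here, the step to compound 2 is the only guide. Within the data shown here, it touches the same 4-hydroxypiperidin-1-yl group but keeps the ring, and no measured compound lacks that ring. With only a 1.3-fold lower number from compound 1 to compound 2 (0.13 log units; within the scatter) to go on, no step beyond the scatter is expected in this assay and neither direction is favoured, though the uncertainty is wide. The estimated step is a 1.1-fold lower number from compound 1 to compound 3 (0.03 log units; within the scatter) and is expected to stay within the scatter. Compound 3 is expected at 5000 nM with an estimated range from 2000 nM to 12000 nM around it.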

Compound 3, half-maximal inhibitory concentration: > 20000 nM
Compound 3 ended at the assay's limit (the forecaster's own chance of this, stated with the estimate: 10%); middle value at least 4.0-fold (0.60 log units) away from the limit.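

In this assay, the change at this position proves not to be silent, and compound 3 stands at a limit of the assay rather than at a number: the limit of > 20000 nM in this assay, at which 1 of the 3 values shown sits. Putting (2-hydroxyethyl)amino in place of 4-hydroxypiperidin-1-yl on a saturated chain carbon bound to an aromatic carbon gives an at least 3.7-fold higher number from compound 1 to compound 3 (0.57 log units; beyond the scatter), and putting it in place of 4-methylpiperidin-1-yl gives an at least 5.0-fold higher number from compound 2 to compound 3 (0.70 log units; beyond the scatter). The earlier pair showed only a change on the ring that stayed within the scatter, a 1.3-fold lower number from compound 1 to compound 2 (0.13 log units; within the scatter), whereas compound 3 keeps a hydroxy group and has no ring, so holding on to a hydroxy group does not by itself keep the number where compound 1 has it.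

The compounds shown cannot say whether the ring itself counts, since the (2-hydroxyethyl)amino group also differs from 4-hydroxypiperidin-1-yl in its heavy atoms and hydrogen-bond donors. Going by these compounds, it remains open whether a smaller ring such as pyrrolidin-1-yl, or an open-chain diethylamino group with no hydroxy, would stay with compound 1 and compound 2 or fall with compound 3.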